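Aryl variation on the saturated ring carbon of the core

The source may report more compounds than this note shows. Statements on the series, on what has been measured and on what is new or still open speak of the compounds shown alone.

Compound 1 `CC(C)=CCOc1ccc2c(c1)OC(c1ccc(F)cc1)CC2=O` is the reference point of this small set. In a functional assay (a lower number here means a stronger inhibitor, a higher number a weaker inhibitor), compound 1 gives 7320 nM, the second highest of three numbers. Compound 2 `CC(C)=CCOc1ccc2c(c1)OC(c1cccc(Cl)c1)CC2=O` gives 6300 nM, and compound 3 `COc1ccc(C2CC(=O)c3ccc(OCC=C(C)C)cc3O2)cc1` gives 10200 nM. The step of a 1.2-fold lower number from compound 1 to compound 2 (0.07 log units; within the scatter) stays within the scatter, as does a 1.4-fold higher number from compound 1 to compound 3 (0.14 log units; within the scatter) and a 1.6-fold higher number from compound 2 to compound 3 (0.21 log units; within the scatter); all three measured pairs differ only in the aryl group on the saturated ring carbon or in the substituent on that aryl group, and none of them moves the number beyond the scatter.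

Compound 4 `CC(C)=CCOc1ccc2c(c1)OC(c1ccc(C)cc1C)CC2=O` is not yet measured. Its change from compound 1 is 2,4-dimethylphenyl in place of 4-fluorophenyl on a saturated ring carbon. The measured steps that bear on it are exactly these aryl exchanges at the same place, and each of them was flat: a chlorine in one position, a fluorine or a methoxy in another, all leaving the number essentially where it was. With no measured aryl exchange at this position exceeding the scatter, the expectation for compound 4 is no step beyond the scatter in this assay in either direction. Compound 4 is therefore estimated at 7000 nM, with a range of 3000 nM to 17000 nM, meaning an expected step of a 1.0-fold lower number from compound 1 to compound 4 (0.02 log units; within the scatter).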

Compound 4, half-maximal inhibitory concentration: 8260 nM
Estimate against measurement, compound 4: 1.2-fold (0.07 log units) below, and the stated range covers the measured number.
By their numbers in this assay, from the lowest: compounds 2, 1, 4 and 3 (each within the scatter of the next).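

In this assay, among these compounds, the 2,4-dimethylphenyl group is the only aryl group in the set with two substituents and the only one carrying neither halogen nor oxygen, yet the steps of a 1.1-fold higher number from compound 1 to compound 4 (0.05 log units; within the scatter) and a 1.2-fold lower number from compound 3 to compound 4 (0.09 log units; within the scatter) and also a 1.3-fold higher number from compound 2 to compound 4 (0.12 log units; within the scatter) all stay within the scatter. All four compounds now lie within the scatter of one another, so the flat behaviour on the saturated ring carbon next to the ring oxygen extends from single substituents on the aryl group to a group with two methyl substituents. No information is available to explain this flatness.

Every aryl group shown is a substituted phenyl with neutral substituents, so it remains open whether a carboxylic acid or a dimethylamino group on that ring, or a pyridine in its place, would move the number in this assay beyond the scatter. The shared core and its ether chain are also constant throughout, leaving open what a shorter chain, a longer chain or a free hydroxyl at that oxygen would do.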